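This account rests on a few compounds, and the source may have more. Where it says the series, first, only, none or still open, it means among the compounds named here.

Of the compounds shown here, three of a shared core have been measured. Compound 1 `ClCc1ccccc1Cn1cnc2c(Cl)nc(Cl)nc21` gives 1580 nM in a functional assay on OVCAR-5 cells (Homo sapiens) for cytotoxicity, read by sulforhodamine B assay, with a stated time of 48 h (a lower number here means a stronger inhibitor of growth, a higher number a weaker inhibitor of growth), compound 2 `ClCc1ccc(Cn2cnc3nc(Cl)nc(Cl)c32)cc1` gives 2180 nM, and compound 3 `Nc1nc(Cl)c2ncn(Cc3cccc(CCl)c3)c2n1` gives 11000 nM. Compound 2 stands second highest of the three numbers, within the scatter of compound 1 and well apart from compound 3. Compound 4 `ClCc1ccc(Cn2cnc3ncnc(Cl)c32)cc1` is not yet measured. It differs from compound 2 by hydrogen in place of chloro on an aromatic carbon. Among the measured compounds shown here, no measured pair shows this change on its own, so no step size can be read from the data. The change removes a chlorine from the core, and a step toward a higher number in this assay is expected, small enough that it may not reach beyond the scatter. Compound 4 is expected to give about 4500 nM, between 1500 nM and 14000 nM, which would mean an expected step of a 2.1-fold higher number from compound 2 to compound 4 (0.31 log units; beyond the scatter).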

Compound 4, concentration for 50% growth inhibition: 6300 nM
Compound 4: the middle estimate sits 1.4-fold (0.15 log units) below what was measured; measured number inside the range.
By their numbers in this assay, from the lowest: compounds 1 and 2 (each within the scatter of the next); then compounds 4 and 3 (each within the scatter of the next).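

Among the compounds shown here, with the first comparison that changes one place only, the chloro group on the aromatic carbon between two ring nitrogen atoms proves to matter in this assay: hydrogen in place of chloro gives a 2.9-fold higher number from compound 2 to compound 4 (0.46 log units; beyond the scatter). The change is modest, but growth inhibition does weaken when this chloro group leaves and the rest of the structure stays the same. No measurement shown accounts for the step. The compounds shown leave open how a fluoro or methoxy group on this carbon would compare with chloro and hydrogen. They also leave open whether the step holds when the chloromethyl group sits elsewhere.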